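Two inactive relatives and a hybrid built from both

This account rests on a few compounds, and the source may have more. Where it says the series, first, only, none or still open, it means among the compounds named here.

Compound 1 `CCCc1nnc(SCC(=O)c2ccc(Cl)cc2)n1N1C(=O)c2ccccc2C1=O` and compound 2 `C=CCSc1nnc(-c2cc(OC)c(OC)c(OC)c2)n1N1C(=O)c2ccccc2C1=O` share a core and were both tested in a functional assay on A549 cells (Homo sapiens) for cytotoxicity, read by MTT assay, with a stated time of 48 h; a lower number here means a stronger inhibitor, a higher number a weaker inhibitor. Compound 1 gives > 200000 nM in this assay, which is a limit of the measurement rather than a number. Compound 2 likewise gives > 200000 nM in this assay, again a limit and not a number. Among the compounds with values here, compound 2 therefore stands at the limit, and the only other value shown sits there as well, as summarised in the limit of > 200000 nM in this assay, at which 2 of the 2 values shown sit. Compound 3 `COc1cc(-c2nnc(SCC(=O)c3ccc(Cl)cc3)n2N2C(=O)c3ccccc3C2=O)cc(OC)c1OC` has not yet been measured. It differs from compound 2 in one place: (4-chlorophenyl)carbonyl in place of vinyl on a saturated chain carbon bound to a sulfur. Within the data shown here, the group that enters is the one compound 1 already carries, while the rest of compound 3 matches compound 2. Among the measured compounds shown here, with no measured step in this set, and both relatives sitting at the limit, no change beyond the usual scatter is expected in either direction. The step that the limit leaves unreadable from compound 2 to compound 3 is therefore expected to be essentially flat. For compound 3 the estimate is 250000 nM, with a range from 100000 nM to 1000000 nM, and the most likely outcome is once more a limit rather than a number.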

Compound 3, half-maximal inhibitory concentration: 9030 nM
Compound 3: middle estimate off by 28-fold (1.44 log units), on the high side, and the stated range ends above it.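

This result shows that the saturated chain carbon bound to a sulfur is not a silent position, as the two limits alone had left possible: in this assay, (4-chlorophenyl)carbonyl in place of vinyl gives an at least 22-fold lower number from compound 2 to compound 3 (1.34 log units; beyond the scatter). The change on the aromatic carbon also matters, since 3,4,5-trimethoxyphenyl in place of propyl gives an at least 22-fold lower number from compound 1 to compound 3 (1.34 log units; beyond the scatter). Each group alone is found in a compound at the limit, so neither is enough by itself in these compounds, and only compound 3, which carries both, gives a number rather than a limit: the limit of > 200000 nM in this assay, at which 2 of the 3 values shown sit.

The compounds shown do not separate the parts of the entering group, so it remains open whether the chlorine, the carbonyl or the aromatic ring is what counts; a plain benzoyl group or a 4-chlorobenzyl group at the same place would begin to tell these apart. As far as these compounds go, it also remains open how much of the 3,4,5-trimethoxyphenyl group is needed, which an unsubstituted phenyl or a 4-methoxyphenyl group in its place would test.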